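Swapping a Flexible Arm for a Directly Attached Pyridine Ring

A few compounds are considered here, and "the series" means these few. Any claim that something is new, unique, unknown or untested is made for them only; others in the source may bear on it.

Compound 2 `Nc1nc(N2CCN(C(=O)COc3ccc(Cl)cc3)CC2)c2nc(CCc3ccc(F)cc3)sc2n1` gives 4400 nM in a functional assay on cells (Lymphocyte, Homo sapiens) (a higher number here means a weaker inhibitor, a lower number a stronger inhibitor), the higher of the two numbers measured. Compound 3 `Nc1nc(N2CCN(C(=O)COc3ccc(Br)cc3)CC2)c2nc(-c3ccc(F)cc3)sc2n1`, which carries an aromatic ring joined directly to the shared core, gives 380 nM in this assay. Compound 1 `Cc1cccc(N2CCN(c3nc(N)nc4sc(-c5ccc(F)cc5)nc34)CC2)c1` reaches only the limit of > 10000 nM in this assay. Going by the values given here, the one single-site step measured, an at least 26-fold lower number from compound 1 to compound 3 (1.42 log units; beyond the scatter), concerns the group on the ring amine and not the site altered here, so no measured step bears directly on compound 4 `Nc1nc(N2CCN(C(=O)COc3ccc(Cl)cc3)CC2)c2nc(-c3ccccn3)sc2n1`, where (pyridin-2-yl in place of 2-(4-fluorophenyl)ethyl on an aromatic carbon). Compound 4 is expected near 900 nM, between 200 nM and 4000 nM, so the estimated step of a 4.9-fold lower number from compound 2 to compound 4 (0.69 log units; beyond the scatter) leans towards a lower number.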

Compound 4, half-maximal inhibitory concentration: 230 nM
Compound 4: the middle estimate sits 3.9-fold (0.59 log units) above what was measured; the range from low to high includes it.
By their numbers in this assay, from the lowest: compounds 4 and 3 (each within the scatter of the next); then compound 2. At a limit, above all of these: compound 1.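

This carbon now has a measured step of its own: pyridin-2-yl in place of 2-(4-fluorophenyl)ethyl gives a 19-fold lower number from compound 2 to compound 4 (1.28 log units; beyond the scatter), so a change at this position alone can strongly shift the number in this assay. The swap removes the chain and adds a hydrogen-bond acceptor, and this single step cannot separate the two. No measurement shown accounts for the gain. Going by these compounds, a plain phenyl ring or a pyridin-3-yl ring here would test whether the ring nitrogen matters, and its placement, so that question remains open.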